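The source may hold more compounds than are shown below. What is called first, only, known or untested is meant among the compounds shown, and "the series" means these compounds.

Compounds with measurements in a functional assay on HepG2 cells (Homo sapiens) for inhibition, read by MTT assay, with a stated time of 72 h; on this read-out lower numbers stand for stronger inhibition and higher numbers for weaker inhibition:

- compound 1 `Nc1ncn(C/C=C2\OC(=O)C(OCc3ccccc3)=C2OCc2ccccc2)c(=O)n1`: 2720 nM
- compound 2 `O=C1O/C(=C\Cn2ccc(NC(=O)c3ccccc3)nc2=O)C(OCc2ccccc2)=C1OCc1ccccc1`: 1980 nM
- compound 3 `NC1(CCn2ncc(=O)[nH]c2=O)OC(=O)C(OCc2ccccc2)=C1OCc1ccccc1`: > 100000 nM

Compound 1 and compound 2 both carry an exocyclic alkene on the lactone and return numbers of similar size in this assay; their two values lie within the scatter of each other, so no order between them is claimed. Compound 3 has a saturated lactone bearing an amino group instead, and for compound 3 the assay gives only a limit, > 100000 nM; this is the limit at which (the limit of > 100000 nM in this assay, at which 1 of the 3 values shown sits). Compound 3 therefore stands apart from compound 1 and compound 2, at the weak end of the numbers shown.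

Compound 4 `Nc1ccn(CCC2(N)OC(=O)C(OCc3ccccc3)=C2OCc2ccccc2)c(=O)n1` keeps the saturated amino lactone of compound 3. The change is a group of 8 heavy atoms (4 carbon, 3 nitrogen, 1 oxygen; one six-membered aromatic ring with 2 hetero atoms) in place of a group of 8 heavy atoms (3 carbon, 3 nitrogen, 2 oxygen; one six-membered aromatic ring with 3 hetero atoms), on a saturated chain carbon, two bonds along the chain from a saturated ring carbon. Within the data shown here, nothing among the measured compounds tracks this exchange on the saturated core, so the step has no measured counterpart. Given that compound 3 sits at > 100000 nM, the step from compound 3 to compound 4 is expected to be small or none beyond the scatter, an at least 1.6-fold lower number from compound 3 to compound 4 (0.22 log units; that floor lies within the scatter), with a fair chance that compound 4 also returns only a limit. Compound 4 is accordingly estimated at 60000 nM in this assay, within 10000 nM to 300000 nM.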

Compound 4, half-maximal inhibitory concentration: > 100000 nM
Compound 4: no number, only a limit; the forecaster's own chance of this, stated with the estimate: 55%; middle value at least 1.6-fold (0.22 log units) from the limit.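

Compound 4 returns only a limit, > 100000 nM. Compound 3 also sits at a limit, so no step can be read between compound 3 and compound 4: the limit of > 100000 nM in this assay, at which 2 of the 4 values shown sit.

The compounds shown leave open how far compound 3 and compound 4 actually lie apart, and whether the same group exchange would register on the core of compound 1.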